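Replacing the ring-bearing group of compound 3

This account rests on a few compounds, and the source may have more. Where it says the series, first, only, none or still open, it means among the compounds named here.

Measured values in a functional assay on HeLa cells (Homo sapiens) for inhibition, read by MTT assay, with a stated time of 48 h (a higher number here means a weaker inhibitor, a lower number a stronger inhibitor), are these
- Compound 1 `CCOC(=O)C1=C(NN=C(C#N)C#N)Nc2[nH]nc(C)c2C1c1ccc(N(C)C)cc1` gives 15200 nM
- Compound 2 `CCOC(=O)C1=C(N/N=C(/Br)c2ccccc2)Nc2[nH]nc(C)c2C1c1ccc(N(C)C)cc1` gives 75700 nM
- Compound 3 `CCOC(=O)C1=C(N/C=N/c2ccc(C)cc2)Nc2[nH]nc(C)c2C1c1ccc(N(C)C)cc1` gives 43200 nM

Compound 3 lies close to compound 2, with a 1.8-fold lower number from compound 2 to compound 3 (0.24 log units; within the scatter), and its number is clearly higher than that of compound 1. Compound 4 `CCOC(=O)C1=C(N/N=C(/Cl)C#N)Nc2[nH]nc(C)c2C1c1ccc(N(C)C)cc1` keeps the shared core but alters one group, as a group of 5 heavy atoms (2 carbon, 2 nitrogen, 1 chlorine; no ring) in place of a group of 9 heavy atoms (8 carbon, 1 nitrogen; one six-membered aromatic ring of carbon only), on an amine nitrogen shows. Like compound 1, it has no ring in that group. Two measured steps introduce a ring there, and both are modest: a 5.0-fold higher number from compound 1 to compound 2 (0.70 log units; beyond the scatter) and a 2.8-fold higher number from compound 1 to compound 3 (0.45 log units; beyond the scatter). Removing the ring may therefore partly reverse them, although the groups differ and the evidence is thin. In this assay the expected change is a 1.8-fold lower number from compound 3 to compound 4 (0.26 log units; within the scatter), a small fall at most. The estimate for compound 4 is 24000 nM, with an expected range of 9000 nM to 65000 nM and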

Compound 4, half-maximal inhibitory concentration: 26200 nM
Estimate against measurement, compound 4: 1.1-fold (0.04 log units) below; the range from low to high includes it.
By their numbers in this assay, from the lowest: compounds 1, 4, 3 and 2 (each within the scatter of the next, the first and the last beyond it).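

In this assay, the ring-free group of compound 4 on the amine nitrogen stands level with the ring-bearing group of compound 3 (a 1.6-fold lower number from compound 3 to compound 4 (0.22 log units; within the scatter)) and with the ring-free group of compound 1 (a 1.7-fold higher number from compound 1 to compound 4 (0.24 log units; within the scatter)). Losing the ring therefore need not shift the number beyond the scatter, although the step from the bromine-bearing group goes against this (a 2.9-fold lower number from compound 2 to compound 4 (0.46 log units; beyond the scatter)). Nothing available gives a reason for these steps.

Still open, on these data alone, is whether a longer chain, an amine or a carboxylic acid on this nitrogen would stand apart from compound 1 and compound 4.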